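Swapping a Methylpyridyl Arm for Fluorophenyl: Cytotoxicity Outlook

The source may hold more compounds than are shown below. What is called first, only, known or untested is meant among the compounds shown, and "the series" means these compounds.

Compound 1 `Cc1cc(-c2ccc3[nH]c(=O)nc(-c4ccccc4)c3c2)ccn1` gives > 50000 nM in an ADME assay on L6 cells (Rattus norvegicus) for cytotoxicity, read by fluorescence and resazurin assay, with a stated time of 72 h (a lower number here means that less compound is needed, a higher number that more compound is needed for the effect), a limit of the measurement rather than a number.
Compound 2 `Cc1ccncc1-c1ccc2[nH]c(=O)nc(-c3ccccc3)c2c1` gives > 50000 nM in this assay, again only a limit.

Both compounds share one core and differ only in the aryl group attached to it. The step from compound 1 to compound 2 is a step that the two limits leave unreadable from compound 1 to compound 2, so it tells nothing about size or direction. Compound 2 therefore stands only at a limit, and the other value shown is a limit as well; both sit at the limit of > 50000 nM in this assay, at which 2 of the 2 values shown sit.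

Compound 3 `O=c1nc(-c2ccccc2)c2cc(-c3ccccc3F)ccc2[nH]1` introduces the change (2-fluorophenyl in place of 4-methylpyridin-3-yl on an aromatic carbon). Within the data shown here, no measured step bears on this change in a readable way: the one step available is unreadable, and both neighbours sit at the same limit. The expectation for compound 3 in this assay is accordingly no step beyond the scatter, with the result most likely reported as a limit again; the estimated step is a step that the limit leaves unreadable from compound 2 to compound 3.

Compound 3 is estimated at 60000 nM, within a range of 20000 nM to 200000 nM.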

Compound 3, half-maximal effective concentration: 55800 nM
Compound 3: middle estimate off by 1.1-fold (0.03 log units), on the high side; the measured number falls inside the stated range.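

The steps from compound 1 and from compound 2 to compound 3 cannot be read, because compound 1 and compound 2 are reported only as a limit: the limit of > 50000 nM in this assay, at which 2 of the 3 values shown sit.

The compounds shown leave open whether 2-fluorophenyl in place of either methylpyridinyl group changes the concentration needed in this assay, and in which direction.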